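This account rests on a few compounds, and the source may have more. Where it says the series, first, only, none or still open, it means among the compounds named here.

In an ADME assay on microsomes from liver (Mus musculus) for metabolic stability, read by LC-MS, with NADPH named in the record, with a stated time of 60 min, tested at 1 uM, in the absence of a further agent (a higher number here means that more of the compound is left, a lower number that less of the compound is left), two compounds on a shared core have been measured so far. Compound 1 `COc1cc(-c2c(C)nc3c(N4CC[C@@H](NC(C)=O)C4)cc(C)nn23)ccc1F` gives > 95%, which is a limit of the assay and not a number. Compound 2 `CC(=O)N[C@@H]1CCN(c2cc(C)nn3c(-c4cccs4)c(C)nc23)C1` gives > 95%, which is again a limit. Compound 2 therefore has no exact position on the scale, and the two compounds share one reading, (the limit of > 95% in this assay, at which 2 of the 2 values shown sit).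

The next compound is compound 3 `CC(=O)N[C@@H]1CCN(c2cc(C)nn3c(-c4ccco4)c(C)nc23)C1`, which differs from compound 2 in one place: furan-2-yl in place of thiophen-2-yl on an aromatic carbon. The exchange lies on an aromatic carbon of a five-membered aromatic ring with 2 nitrogen, part of a fused or bridged system of two rings. For the measured compounds named here, the only measured step that bears on it is a step that the two limits leave unreadable from compound 1 to compound 2, a change on that same aromatic carbon. Going by the values given here, with that step as the only guide, no change beyond the scatter, in either direction, is expected in this assay. The expected step is a number at least 3 percentage points lower from compound 2 to compound 3 (that floor lies within the scatter). For compound 3 the estimate is 92%, with an expected range from 78% to 100%.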

Compound 3, percent of the compound remaining: > 95%
Compound 3 ended at the assay's limit; the forecaster's own chance of this, stated with the estimate: 50%; middle value at least 3 percentage points from the limit.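

In this assay compound 3 gives > 95%, which is a limit of the assay and not a number. No step between compound 3 and compound 2 or compound 1 can be read, and the three compounds share one reading: the limit of > 95% in this assay, at which 3 of the 3 values shown sit.

The compounds shown leave open whether the three groups on that aromatic carbon differ at all in this assay.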